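The compounds below may be only part of what the source reports. "The series", "measured", "known", "first", "only" and "open" are said of these compounds alone.

Of the compounds shown here, two have a value so far. In an ADME assay on C8166 cells (Homo sapiens) for cytotoxicity, read by colorimetric assay and MTT assay (a higher number here means that more compound is tolerated, a lower number that less compound is tolerated), compound 2 `Cc1cccc(C(=O)c2c(OCC(=O)Nc3ccc(S(N)(=O)=O)cc3C)ccc3cc(C#N)ccc23)c1` gives 15200 nM, the lowest of the two numbers. The nearest neighbour, compound 1 `Cc1ccc(C(=O)c2c(OCC(=O)Nc3ccc(S(N)(=O)=O)cc3C)ccc3cc(Br)ccc23)cc1C`, gives 85200 nM in this assay, a gap beyond the scatter; the two differ in more than one place, so nothing can be said about either change on its own.

Compound 3 `Cc1ccc(C(=O)c2c(OCC(=O)Nc3ccc(S(N)(=O)=O)cc3C)ccc3cc(C#N)ccc23)cc1C` has not yet been measured. It differs from compound 2 by methyl in place of hydrogen on an aromatic carbon. Compound 3 therefore carries the 3,4-dimethylphenyl group of compound 1 together with the nitrile of compound 2.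

Among the compounds with values here, no single-change step is available to anchor an expectation. Compound 3 is expected to move up slightly from compound 2, by about a 1.4-fold higher number from compound 2 to compound 3 (0.16 log units; within the scatter), a step of a size that may still lie within the scatter. Compound 3 is estimated at 22000 nM in this assay, in a range from 9000 nM to 55000 nM.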

Compound 3, half-maximal cytotoxic concentration: > 379000 nM
Compound 3 ended at the assay's limit (the forecaster's own chance of this, stated with the estimate: 5%); middle value at least 17-fold (1.23 log units) from the limit.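

In this assay, within the data shown here, the change from 3-methylphenyl to 3,4-dimethylphenyl, with the nitrile held constant, gives an at least 24-fold higher number from compound 2 to compound 3 (1.39 log units; beyond the scatter), the first reading of a single change at this position and one far larger than the earlier pair could reveal. With the 3,4-dimethylphenyl group held constant, the other single change gives an at least 4.4-fold higher number from compound 1 to compound 3 (0.64 log units; beyond the scatter), so the nitrile is also linked to more compound being tolerated on this background, whereas compound 2 alone had the lower number. The result for compound 3 is a limit of the assay and not a number, so both steps give only a lower bound: the limit of > 379000 nM in this assay, at which 1 of the 3 values shown sits.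

From the compounds shown here alone, it remains open whether the methyl step would keep its size with bromo in place of the nitrile, and whether a chloro or methoxy group on that aromatic carbon would act as methyl does. The true value of compound 3 also remains open, as does any reason for either step.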